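Naphthyl in place of cyanobenzyl: an expected solubility shift

A few compounds are considered here, and "the series" means these few. Any claim that something is new, unique, unknown or untested is made for them only; others in the source may bear on it.

Compound 3 `COc1cccc(CNCCCNc2ccnc3cc(Cc4ccc(C#N)cc4)ccc23)c1O` stands at the bottom of the three numbers measured. In a physicochemical assay for solubility, with a stated time of 18 h, at pH 7.4 (on this read-out lower numbers stand for lower solubility and higher numbers for higher solubility), compound 3 gives 4200 nM, level with compound 1 `COc1cccc(CNCCCNc2ccnc3cc(Cc4ccccc4)ccc23)c1O`, which in this assay gives 4200 nM. Compound 2 `COc1cccc(Oc2ccc3c(NCCCNCc4cccc(OC)c4O)ccnc3c2)c1` gives 14500 nM in this assay, and a 3.5-fold lower number from compound 2 to compound 3 (0.54 log units; beyond the scatter).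

Compound 4 `COc1cccc(CNCCCNc2ccnc3cc(-c4cccc5ccccc45)ccc23)c1O` differs from compound 3 in a single place: naphthalen-1-yl in place of 4-cyanobenzyl on an aromatic carbon.

Within the data shown here, two measured steps bear on this change. First, no change at the digits printed from compound 1 to compound 3 (within the scatter), so the nitrile on the benzyl group added nothing to the read-out, and its loss alone should cost little. Second, a 3.5-fold higher number from compound 1 to compound 2 (0.54 log units; beyond the scatter), which shows that exchanging the whole group at this position of the shared core can shift the number modestly. Among the measured compounds shown here, no measured step places a second fused aromatic ring at this position, so the account rests on these two comparisons only. The writer expects a step downward in this assay that is small and close to the scatter, estimated as a 1.7-fold lower number from compound 3 to compound 4 (0.23 log units; within the scatter). For compound 4 the estimated value in this assay is 2500 nM, with a range from 800 nM to 8000 nM.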

Compound 4, solubility: 32000 nM
For compound 4 the middle estimate is 13-fold (1.11 log units) below the measured one; measured number above the stated range.
By their numbers in this assay, from the lowest: compounds 1 and 3 (each within the scatter of the next); then compound 2; then compound 4.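

In this assay, among these compounds, naphthalen-1-yl at this position gives a larger step than any seen among the earlier compounds (a 7.6-fold higher number from compound 3 to compound 4 (0.88 log units; beyond the scatter)), and the step against the unsubstituted benzyl group is of the same size (a 7.6-fold higher number from compound 1 to compound 4 (0.88 log units; beyond the scatter)). It also carries the number past the 3-methoxyphenoxy group (a 2.2-fold higher number from compound 2 to compound 4 (0.34 log units; beyond the scatter)), so compound 4 now holds the highest number of the four and the earlier ceiling at this position no longer stands. Nothing measured here says why a group with two six-membered aromatic rings of carbon only gives this rise.

The compounds shown leave open whether the rise follows from the second aromatic ring or from losing the methylene link of the benzyl groups, since compound 4 differs from compound 1 in both respects at once. A plain phenyl group or naphthalen-2-yl at this place would help to separate these two readings, and a morpholine or a carboxylic acid on the same carbon would show how far the range at this position extends.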